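Compound 3: 2-amino-5-methoxyphenyl in place of methylcarbamoyl

A few compounds are considered here, and "the series" means these few. Any claim that something is new, unique, unknown or untested is made for them only; others in the source may bear on it.

In a functional assay on blood (Homo sapiens), with a stated time of 60 min, in the presence of a further agent that is not named here (on this read-out higher numbers stand for an effect only at larger amounts of compound and lower numbers for an effect already at smaller amounts), compound 2 `CNC(=O)NC(=O)C1(S(=O)(=O)c2ccc(Oc3ccc(OC(F)(F)F)cc3)cc2)CCC2(CCNCC2)C1` gives < 400 nM, which is a limit of the assay and not a number. Compound 1 `O=S(=O)(c1ccc(Oc2ccc(OC(F)(F)F)cc2)cc1)C1(CO)CCC2(CCNCC2)C1` gives > 15000 nM, also a limit. Within the data shown here, the only measured step runs an at least 37-fold lower number from compound 1 to compound 2 (1.57 log units; beyond the scatter), large and beyond the scatter, with (methylcarbamoyl)carbamoyl in place of hydroxymethyl on a saturated ring carbon.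

Compound 3 `COc1ccc(N)c(NC(=O)C2(S(=O)(=O)c3ccc(Oc4ccc(OC(F)(F)F)cc4)cc3)CCC3(CCNCC3)C2)c1` carries 2-amino-5-methoxyphenyl in place of methylcarbamoyl on an amide-type nitrogen. The step of an at least 37-fold lower number from compound 1 to compound 2 (1.57 log units; beyond the scatter) replaced the whole substituent, whereas this change affects only its outer part, so that step bears only indirectly. Among the measured compounds shown here, no measured step covers this exchange alone. A smaller step towards a higher number is expected in this assay. The estimated step runs an at least 2.2-fold higher number from compound 2 to compound 3 (0.35 log units; beyond the scatter). For compound 3 the expected value is 900 nM, with an estimated range of 120 nM to 7000 nM.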

Compound 3, half-maximal effective concentration: 3700 nM
Compound 3: middle estimate off by 4.1-fold (0.61 log units), on the low side, within the range that was stated.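

At this position the outer part of the substituent counts on its own: 2-amino-5-methoxyphenyl in place of methylcarbamoyl on an amide-type nitrogen gives an at least 9.2-fold higher number from compound 2 to compound 3 (0.96 log units; beyond the scatter) in this assay, while (2-amino-5-methoxyphenyl)carbamoyl in place of hydroxymethyl still gives an at least 4.0-fold lower number from compound 1 to compound 3 (0.60 log units; beyond the scatter), so the lower number relative to hydroxymethyl does not depend on methylcarbamoyl alone. One end of the first step is a limit of the assay and not a number: the limit of < 400 nM in this assay, at which 1 of the 3 values shown sits. One end of the second step is likewise a limit of the assay and not a number: the limit of > 15000 nM in this assay, at which 1 of the 3 values shown sits.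

Which part of 2-amino-5-methoxyphenyl carries the step stays open, since the ring, the amino group and the methoxy group enter together. A plain phenyl or a 2-aminophenyl group on the same nitrogen would separate these contributions.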